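A few compounds are considered here, and "the series" means these few. Any claim that something is new, unique, unknown or untested is made for them only; others in the source may bear on it.

Of the compounds shown here, two built on the shared core have so far been measured in a toxicity assay on MCF-10A cells (Homo sapiens) for inhibition, read by MTT assay, with a stated time of 72 h; a lower number here means a stronger inhibitor of growth, a higher number a weaker inhibitor of growth. Compound 1, `O=S(=O)(NCCNCc1cccc2ccccc12)c1cc(C(F)(F)F)cc(C(F)(F)F)c1`, gives 22000 nM. Compound 2, `COc1ccc(CNCCCNS(=O)(=O)c2cc(C(F)(F)F)cc(C(F)(F)F)c2)cc1OC`, gives 5300 nM, the lower of the two numbers, and its gap to compound 1 lies beyond the usual scatter, so compound 2 stands as the stronger growth inhibitor of this pair. Compound 3, `O=S(=O)(NCCCNCc1ccc(Br)cc1)c1cc(C(F)(F)F)cc(C(F)(F)F)c1`, has not yet been measured in this assay. It differs from compound 2 in a single place: 4-bromophenyl in place of 3,4-dimethoxyphenyl on a saturated chain carbon bound to an amine nitrogen. Within the data shown here, no measured pair shows this same change, so its effect cannot be read from the numbers at hand, and compound 1 and compound 2 differ from each other in more than one place, which leaves little to lean on. The expected step of a 1.5-fold higher number from compound 2 to compound 3 (0.18 log units; within the scatter) is therefore modest, toward a somewhat higher number, and may well stay within the scatter. For compound 3 the estimated value in this assay is 8000 nM, with a likely range from 2500 nM to 25000 nM.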

Compound 3, concentration for 50% growth inhibition: 3100 nM
Compound 3: the middle estimate sits 2.6-fold (0.41 log units) above what was measured; low and high end bracket the measured number.
By their numbers in this assay, from the lowest: compounds 3 and 2 (each within the scatter of the next); then compound 1.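

In this assay, replacing the 3,4-dimethoxyphenyl group with 4-bromophenyl gives a 1.7-fold lower number from compound 2 to compound 3 (0.23 log units; within the scatter), so the two numbers cannot be told apart. Among these compounds, this is the first measured change at this place, on a saturated chain carbon bound to an amine nitrogen, and it shows that a large change in the group leaves the reading within the scatter: 10 heavy atoms with 2 hydrogen-bond acceptors give way to 7 heavy atoms with 0 hydrogen-bond acceptors, and the aromatic ring of carbon stays. Nothing measured here speaks to why the numbers for these two compounds lie so close together.

As far as these compounds go, compound 1 differs from compound 2 and compound 3 in more than one place, so any step to it cannot be read, and the separate contributions of its chain and its aromatic group remain unknown. Also open, from the compounds shown here alone, is whether this place would accept a group of a quite different kind, such as a carboxylic acid or an amine in place of the 4-bromophenyl group, with as little change in the number.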